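Phenyl in Place of Benzyl: Estimating Compound 4

A few compounds are considered here, and "the series" means these few. Any claim that something is new, unique, unknown or untested is made for them only; others in the source may bear on it.

Measured so far in an assay on isolated protein for inhibition of Polyunsaturated fatty acid 5-lipoxygenase (Rattus norvegicus); a lower number here means a stronger inhibitor, a higher number a weaker inhibitor:
Compound 1 `NC(=O)N(O)C1CCCc2ccccc21`: 29000 nM
Compound 2 `NC(=O)N(O)C1CCCc2c(OCc3ccccc3)cccc21`: 910 nM
Compound 3 `COc1ccc(COc2cccc3c2CCCC3N(O)C(N)=O)cc1`: 500 nM

Compound 2 stands second highest of the three numbers; compound 3 is nearest, while compound 1, which lacks the oxygen-linked benzyl, is furthest and clearly weaker. Compound 4 `NC(=O)N(O)C1CCCc2c(Oc3ccccc3)cccc21` differs from compound 2 in one place: phenyl in place of benzyl on an oxygen on an aromatic ring. For the measured compounds named here, the only measured step, a 1.8-fold lower number from compound 2 to compound 3 (0.26 log units; within the scatter), alters the benzyl ring itself and lies within the scatter, so it says little about removing the carbon that links oxygen to the ring. Going by the values given here, no measured pair tests that shortening directly; the values of compound 1 and compound 2 show only that the oxygen-linked group matters greatly. For compound 4 a modest weakening is expected, a 2.0-fold higher number from compound 2 to compound 4 (0.30 log units; within the scatter), giving an estimate of 1800 nM with a range from 450 nM to 7000 nM.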

Compound 4, half-maximal inhibitory concentration: 840 nM
Compound 4: middle estimate off by 2.1-fold (0.33 log units), on the high side; the range from low to high includes it.
By their numbers in this assay, from the lowest: compounds 3, 4 and 2 (each within the scatter of the next); then compound 1.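

In this assay, phenyl in place of benzyl on this oxygen gives a 1.1-fold lower number from compound 2 to compound 4 (0.03 log units; within the scatter), so compound 2 and compound 4 cannot be told apart and the shorter link is tolerated here. The phenoxy group alone still accounts for a large gain over the bare core, a 35-fold lower number from compound 1 to compound 4 (1.54 log units; beyond the scatter). Nothing at hand explains why phenyl and benzyl match. Open, as far as these compounds go, is whether this oxygen needs an aromatic ring at all, since a longer chain or an amine-bearing chain in its place would test that.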